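Chain extension at the amide carbonyl, compound 3 to compound 4

The source may hold more compounds than are shown below. What is called first, only, known or untested is meant among the compounds shown, and "the series" means these compounds.

Within the data shown here, compound 3 `C=CC(=O)Nc1cccc(Oc2nc(Nc3cccc(C#N)c3)nc3ccsc23)c1` gives 6390 nM in a functional assay on HeLa cells (Homo sapiens) for inhibition, read by MTT assay, with a stated time of 72 h (a higher number here means a weaker inhibitor, a lower number a stronger inhibitor), the lowest of the three numbers so far. Compound 1 `C=CC(=O)Nc1cccc(Oc2nc(Nc3cccc(OC)c3)nc3ccsc23)c1` gives 16400 nM and compound 2 `COc1cccc(Nc2nc(Oc3cccc(NC(=O)C=C(C)C)c3)c3sccc3n2)c1` gives 26100 nM; the step of a 2.6-fold lower number from compound 1 to compound 3 (0.41 log units; beyond the scatter) lies beyond the scatter, and compound 2 sits further off still. Compound 4 `CCC/C=C/C(=O)Nc1cccc(Oc2nc(Nc3cccc(C#N)c3)nc3ccsc23)c1` is not yet measured; it differs from compound 3 by pent-1-en-1-yl in place of vinyl on a carbonyl carbon. Among the measured compounds shown here, one measured step bears on this place: a 1.6-fold higher number from compound 1 to compound 2 (0.20 log units; within the scatter), where a 2-methylprop-1-en-1-yl group replaced the vinyl on the carbonyl carbon and the number stayed within the scatter. The pent-1-en-1-yl group is a longer replacement at the same carbonyl carbon, so no step beyond the scatter is expected for a 1.4-fold higher number from compound 3 to compound 4 (0.15 log units; within the scatter), with a slight drift toward a higher number allowed because of a 1.6-fold higher number from compound 1 to compound 2 (0.20 log units; within the scatter). Compound 4 is therefore estimated at 9000 nM, with a range from 4000 nM to 22000 nM.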

Compound 4, half-maximal inhibitory concentration: 42100 nM
The estimate for compound 4 lay 4.7-fold (0.67 log units) below the measured number; measured number outside the range, above it.
By their numbers in this assay, from the lowest: compound 3; then compounds 1, 2 and 4 (each within the scatter of the next, the first and the last beyond it).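

In this assay the amide carbonyl carbon proves sensitive to what replaces vinyl: with pent-1-en-1-yl the result is a 6.6-fold higher number from compound 3 to compound 4 (0.82 log units; beyond the scatter), and this step lies beyond the scatter. The earlier replacement, 2-methylprop-1-en-1-yl, gave only a 1.6-fold higher number from compound 1 to compound 2 (0.20 log units; within the scatter), so the within-scatter result for that group does not extend to every chain at this carbon. No measurement shown here accounts for the step.

Going by these compounds, the two steps start from different aromatic substituents, methoxy and cyano, so it remains open whether the chain and that substituent act independently. Also open, on these data alone, is whether an intermediate chain such as prop-1-en-1-yl, or a chain ending in a dimethylamino group, would keep the number close to that of compound 3 at 6390 nM in this series.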